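This account rests on a few compounds, and the source may have more. Where it says the series, first, only, none or still open, it means among the compounds named here.

Measured in a functional assay on HepG2 cells (Homo sapiens) for antiproliferative activity, read by MTT assay; on this read-out higher numbers stand for weaker inhibition and lower numbers for stronger inhibition:
- compound 1 `Cc1ccc(-n2cc(COc3ccc(/C=C/C(=O)c4cc5c(cc4O)OC(C)(C)CC5)cc3)nn2)cc1Br` gives 117000 nM
- compound 2 `CCCCCn1cc(COc2ccc(/C=C/C(=O)c3cc4c(cc3O)OC(C)(C)CC4)cc2)nn1` gives 95800 nM

Compound 2 stands within the scatter of compound 1, so the two values cannot be ranked. Compound 3 `CCCCCCCCn1cc(COc2ccc(/C=C/C(=O)c3cc4c(cc3O)OC(C)(C)CC4)cc2)nn1` differs from compound 2 by propyl in place of hydrogen on a saturated chain carbon, five bonds along the chain from an aromatic nitrogen. Among the compounds with values here, the only measured step that bears on this is a 1.2-fold lower number from compound 1 to compound 2 (0.09 log units; within the scatter), a change of pentyl for 3-bromo-4-methylphenyl on an aromatic nitrogen. No change along the chain itself has been measured. No shift beyond the scatter is therefore expected in this assay. The expected step is a 1.2-fold lower number from compound 2 to compound 3 (0.08 log units; within the scatter). Compound 3 is estimated at 80000 nM, with an expected range from 35000 nM to 160000 nM.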

Compound 3, half-maximal inhibitory concentration: 127000 nM
Estimate against measurement, compound 3: 1.6-fold (0.20 log units) below; low and high end bracket the measured number.
By their numbers in this assay, from the lowest: compounds 2, 1 and 3 (each within the scatter of the next).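

In this assay, within the data shown here, propyl in place of hydrogen on the saturated chain carbon, five bonds along the chain from an aromatic nitrogen, is the first replacement on the chain itself to be measured, and it gives a 1.3-fold higher number from compound 2 to compound 3 (0.12 log units; within the scatter) within the scatter. Octyl in place of 3-bromo-4-methylphenyl, with a 1.1-fold higher number from compound 1 to compound 3 (0.04 log units; within the scatter) also within the scatter, gives an alkyl chain and an aryl group that cannot be ranked here. No evidence is available to explain these values.
The compounds shown leave open whether a decyl chain, an amine or a carboxylic acid on that aromatic nitrogen would give a number beyond the scatter.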